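This account rests on a few compounds, and the source may have more. Where it says the series, first, only, none or still open, it means among the compounds named here.

Going by the values given here, compound 1 `CCCCN(CC)c1cc(C)nc2c1NC(=O)CN2c1ccc(Br)cc1Br` is the only member of the series with a number in an assay on HEK-293T cells for displacement of a labelled ligand from corticotropin-releasing factor receptor 2 (Homo sapiens), read by scintillation counting, with a stated time of 2 h, tested at 1 uM; on this read-out lower numbers stand for less inhibition and higher numbers for more inhibition at the one concentration tested (going by the name of the read-out): compound 1 gives 9.4%, so it stands alone and low on this read-out. Compound 2 `CCCCN(CC)c1cc(C)nc2c1NC(=O)CN2c1ccc(Cl)cc1Br` has no result in this assay, recorded as "not determined" (no result reported). Compound 3 `CCCCN(CC)c1cc(C)nc2c1NC(=O)CN2c1ccc(C)cc1C` is yet to be tested in this assay. Its change from compound 1 is 2,4-dimethylphenyl in place of 2,4-dibromophenyl on a nitrogen on an aromatic ring in a ring. Among the compounds with values here, no pair of measured compounds shows such a step, so the expectation is a shift of a number 0.6 percentage points higher from compound 1 to compound 3 (within the scatter), which is none beyond the scatter. Compound 3 is expected to give about 10% in this assay, within 0% to 30%.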

Compound 3, a percentage reported as inhibition, at one concentration (the size of the read-out at that concentration, not a potency): 6.8%
The estimate for compound 3 lay 3.2 percentage points above the measured number; measured number inside the range.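

In this assay, going by these compounds alone, 2,4-dimethylphenyl in place of 2,4-dibromophenyl on this nitrogen gives a number 2.6 percentage points lower from compound 1 to compound 3 (within the scatter), the first step that can be read. Exchanging both bromine atoms for carbon at an unchanged heavy-atom count therefore does not separate the two compounds on this read-out. No measured evidence bears on this result.

As far as these compounds go, whether a carboxylic acid or an amine in place of the two methyl groups would shift the number remains open. From the compounds shown here alone, the effect of changes elsewhere on the shared core also remains open.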